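The compounds below may be only part of what the source reports. "The series", "measured", "known", "first", "only" and "open" are said of these compounds alone.

Working notes on the series.

The series is followed in an ADME assay on Vero cells (Chlorocebus sabaeus) for cytotoxicity, read by MTT assay, with a stated time of 72 h; a lower number here means that less compound is needed, a higher number that more compound is needed for the effect. Of the compounds shown here, two have numbers so far. Compound 1 `O=C(Nc1nc(-c2ccccn2)cs1)c1cccc(OCc2ccccc2)c1` gives 14400 nM in this assay, which is the highest of the two numbers. Compound 2 `O=C(Nc1nc(-c2ccccn2)cs1)c1ccc(OCc2ccccc2)cc1` gives 2300 nM in this assay, and the gap between compound 1 and compound 2 lies beyond the scatter of repeated measurements. Among the compounds with values here, no step between two measured compounds that differ in a single place is available, so nothing is yet known about how one change on the shared core shifts the number.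

Compound 3 `CC(=O)c1cccc(C(=O)Nc2nc(-c3ccccn3)cs2)c1` is the next one to be measured in this assay. It differs from compound 1 in one place: acetyl in place of benzyloxy on an aromatic carbon. The entering group is small and has no ring, and the change sits meta to a large group.

Within the data shown here, with no single-point step to lean on, the expectation for compound 3 is a step from compound 1 that is modest, a 1.4-fold higher number from compound 1 to compound 3 (0.14 log units; within the scatter), most likely no change beyond the scatter or a slight rise. Compound 3 is therefore estimated at 20000 nM in this assay, within a range of 6000 nM to 60000 nM.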

Compound 3, half-maximal effective concentration: 1500 nM
Estimate against measurement, compound 3: 13-fold (1.12 log units) above; the measured number lies below the stated range.
By their numbers in this assay, from the lowest: compounds 3 and 2 (each within the scatter of the next); then compound 1.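

Working notes, continued.

Acetyl in place of benzyloxy on this aromatic carbon gives a 9.6-fold lower number from compound 1 to compound 3 (0.98 log units; beyond the scatter) in this assay and is the first single-place step in the series, showing that the group at this place, meta to a large group, can by itself move the number beyond the scatter. The direction is toward less compound being needed for the effect, so the large benzyloxy group is not needed at this place for a low number in this assay. The change removes a group of 8 heavy atoms with a six-membered aromatic ring and brings in one of 3 heavy atoms with no ring and one double bond outside aromatic rings, while the count of hydrogen-bond acceptors stays the same and neither group carries a net charge; no measurement at hand gives a reason for the shift.

As far as these compounds go, it remains open whether the step goes with the loss of the ring or with the arrival of the carbonyl, and a methoxy group or a phenyl ketone on the same aromatic carbon would help to separate the two. Also open, from the compounds shown here alone, is how an amine or a carboxylic acid at this place would compare with acetyl and benzyloxy.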